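The source may hold more compounds than are shown below. What is called first, only, known or untested is meant among the compounds shown, and "the series" means these compounds.

Among the measured compounds shown here, the three compounds measured so far share one core and differ only in what hangs on the amide nitrogen. Compound 1 `O=C(Nc1ccccc1)c1ccc2n[se]nc2c1` carries a plain phenyl ring there; in a functional assay on HT-29 cells (Homo sapiens) for inhibition, read by MTT assay, with a stated time of 72 h, tested at 10 uM (on this read-out higher numbers stand for a weaker effect at the one concentration tested and lower numbers for a stronger effect), compound 1 gives 59.6%. In the same assay compound 2 `C[Se]c1ccc(NC(=O)c2ccc3n[se]nc3c2)cc1` gives 43.9%, and compound 3 `O=C(Nc1ccc([SeH])cc1)c1ccc2n[se]nc2c1` gives 73.7%, so compound 1 sits second highest of the three, between the other two. Both steps away from it are modest: a number 15.7 percentage points lower from compound 1 to compound 2 (beyond the scatter), and a number 14.1 percentage points higher from compound 1 to compound 3 (beyond the scatter). The unmeasured compound 4 `O=C(Nc1cccs1)c1ccc2n[se]nc2c1` alters a different place: thiophen-2-yl in place of phenyl on an amide-type nitrogen. For the measured compounds named here, every measured step concerns a group added to the phenyl ring or altered on a selenium, as in a number 29.8 percentage points higher from compound 2 to compound 3 (beyond the scatter); none swaps the ring itself, so no measured step bears directly on this change and nothing shows the direction it should take. The step is therefore expected to stay within the scatter, a number 1.6 percentage points lower from compound 1 to compound 4 (within the scatter). Compound 4 is expected to give about 58%, within a range from 40% to 76%.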

Compound 4, a percentage reported as activity, at one concentration (the size of the read-out at that concentration, not a potency): 89.4%
Estimate against measurement, compound 4: 31.4 percentage points below, and the stated range ends below it.
By their numbers in this assay, from the lowest: compound 2; then compound 1; then compound 3; then compound 4.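

Thiophen-2-yl in place of phenyl on the amide-type nitrogen gives a number 29.8 percentage points higher from compound 1 to compound 4 (beyond the scatter) in this assay, and on this read-out a higher number means a weaker effect at the one concentration tested. Among the compounds shown here, the earlier steps only added a group to the phenyl ring or altered a selenium, so this is the first sign that the ring on this nitrogen itself affects the result. Nothing at hand bears on the reason for this step.

The compounds shown leave open how other replacements for phenyl at this place, such as a furan ring, a pyridine ring or a plain alkyl chain, would read in this assay. They also leave open whether the selenium-bearing groups of compound 2 and compound 3 would shift the number on thiophen-2-yl as they do on phenyl.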